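This account rests on a few compounds, and the source may have more. Where it says the series, first, only, none or still open, it means among the compounds named here.

Three compounds have been measured in a functional assay on COLO 205 cells (Homo sapiens) for cytotoxicity, read by MTT assay, with a stated time of 24 h; on this read-out lower numbers stand for stronger inhibition and higher numbers for weaker inhibition:

Compound 1 `OCc1cc2ccccc2nc1-c1ccccc1O`: 40000 nM
Compound 2 `OCc1cc2cc(Cl)ccc2nc1-c1ccccc1O`: 24000 nM
Compound 3 `[N-]=[N+]=NCc1cc2ccccc2nc1-c1ccccc1O`: 19000 nM

Among the measured compounds shown here, compound 3 carries the lowest number of the three, though its gap to compound 2 lies within the scatter; only the step of a 2.1-fold lower number from compound 1 to compound 3 (0.32 log units; beyond the scatter) reaches beyond it. Compound 4 `NCc1cc2ccccc2nc1-c1ccccc1O` differs from compound 3 by amino in place of azido on a saturated chain carbon bound to an aromatic carbon. For the measured compounds named here, the one measured step at that same place, a 2.1-fold lower number from compound 1 to compound 3 (0.32 log units; beyond the scatter), was modest, and the step of a 1.7-fold lower number from compound 1 to compound 2 (0.22 log units; within the scatter) elsewhere stayed within the scatter. Going by the values given here, no measured pair swaps azido for amino, so in this assay only a small step, in either direction, is expected from compound 3 to compound 4, a 1.3-fold higher number from compound 3 to compound 4 (0.12 log units; within the scatter). Compound 4 is therefore estimated at 25000 nM, within 8000 nM to 70000 nM.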

Compound 4, half-maximal inhibitory concentration: 32000 nM
Beside the measured number, compound 4's estimate is 1.3-fold (0.11 log units) below it, and the stated range covers the measured number.
By their numbers in this assay, from the lowest: compounds 3, 2, 4 and 1 (each within the scatter of the next, the first and the last beyond it).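

At this place on a saturated chain carbon bound to an aromatic carbon, amino gives only small steps in this assay: a 1.7-fold higher number from compound 3 to compound 4 (0.23 log units; within the scatter) and a 1.3-fold lower number from compound 1 to compound 4 (0.10 log units; within the scatter). Compound 4 therefore cannot be told apart from either compound, even though hydroxy and azido themselves differ just beyond the scatter. No evidence here explains these small steps. Still open, as far as these compounds go, is whether a carboxylic acid or a longer chain at this place would give a larger step, and whether amino behaves the same on the chloro core of compound 2.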